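The source may report more compounds than this note shows. Statements on the series, on what has been measured and on what is new or still open speak of the compounds shown alone.

Compound 1, with the structure `Clc1nss/c1=N\c1ccc(OCc2ccccc2)cc1`, carries a benzyloxy group on the aromatic ring. In a functional assay on PANC-1 cells (Homo sapiens) for cytotoxicity, read by resazurin assay, with a stated time of 72 h (a lower number here means a stronger inhibitor, a higher number a weaker inhibitor), compound 1 gives > 100000 nM, which is a limit of the assay rather than a number. Compound 2, with the structure `CCCCOc1ccc(/N=c2\ssnc2Cl)cc1`, differs from it by propyl in place of phenyl on a saturated chain carbon bound to an oxygen on an aromatic ring. In this assay compound 2 gives > 100000 nM, again a limit of the assay and not a number. The step that the two limits leave unreadable from compound 1 to compound 2 therefore cannot be read, since the limit of > 100000 nM in this assay, at which 2 of the 2 values shown sit, describes both values. Compound 2 thus stands at the limit, with no measured number for it.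

Compound 3, with the structure `CSc1ccc(/N=c2\ssnc2Cl)cc1`, differs from compound 2 by methylsulfanyl in place of butoxy on an aromatic carbon. For the measured compounds named here, no measured step bears on this change, and the only step at hand is unreadable because the limit of > 100000 nM in this assay, at which 2 of the 2 values shown sit, covers both compounds. The expected step of a number no higher from compound 2 to compound 3 (the limit leaves the size open) is therefore none beyond the scatter. Compound 3 is expected to give 100000 nM in this assay, with a range from 20000 nM to 500000 nM.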

Compound 3, half-maximal inhibitory concentration: 86000 nM
For compound 3 the middle estimate is 1.2-fold (0.07 log units) above the measured one, within the range that was stated.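

In this assay, for the compounds shown here, compound 3 gives 86000 nM, the first actual number. Compound 1 and compound 2 offered only limits of the assay. At this aromatic carbon, methylsulfanyl with 2 heavy atoms replaces butoxy with 5, and the change gives an at least 1.1-fold lower number from compound 2 to compound 3 (0.06 log units; that floor lies within the scatter), so the smallest step the data allow cannot be told apart from the ordinary spread of repeated measurements. The true size of the step stays unknown because compound 2 has only a limit of the assay and no number: the limit of > 100000 nM in this assay, at which 2 of the 3 values shown sit.

The compounds shown leave open how an amine or a carboxylic acid on this same aromatic carbon would compare with methylsulfanyl in this cell assay. They also leave open how a methoxy group would read here, a comparison that would help separate the swap of sulfur for oxygen from the shortening of the chain.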